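Urea to sulfamide on the piperidine nitrogen

A few compounds are considered here, and "the series" means these few. Any claim that something is new, unique, unknown or untested is made for them only; others in the source may bear on it.

Compound 1 `O=C(/C(=N/O)Nc1ccc(F)c(Br)c1)C1CCN(C(=O)NCc2ccccc2)CC1` gives 89800 nM in an assay for inhibition of Tryptophan 2,3-dioxygenase (Homo sapiens), with a stated time of 1 h; on this read-out higher numbers stand for weaker inhibition and lower numbers for stronger inhibition.
Compound 2 `O=C(/C(=N/O)Nc1ccc(F)c(Br)c1)C1CCN(C(=O)Nc2ccccc2)CC1` gives 58000 nM in this assay.

For the measured compounds named here, compound 2 holds the lowest of the two numbers, and its only neighbour is compound 1, at a gap within the scatter. Compound 3 `O=C(/C(=N/O)Nc1ccc(F)c(Br)c1)C1CCN(S(=O)(=O)Nc2ccccc2)CC1` differs from compound 2 by phenylsulfamoyl in place of phenylcarbamoyl on an amine nitrogen in a ring. Going by the values given here, the one measured step, a 1.5-fold lower number from compound 1 to compound 2 (0.19 log units; within the scatter), concerns a different place and a different kind of swap, so nothing measured speaks directly to a sulfamoyl for carbamoyl exchange. Compound 3 is therefore expected to stay near compound 2, with a step of a 1.0-fold higher number from compound 2 to compound 3 (0.01 log units; within the scatter). The estimate for compound 3 is 60000 nM, within 20000 nM to 180000 nM.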

Compound 3, half-maximal inhibitory concentration: 65700 nM
Estimate against measurement, compound 3: 1.1-fold (0.04 log units) below; the measured number falls inside the stated range.
By their numbers in this assay, from the lowest: compounds 2, 3 and 1 (each within the scatter of the next).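

Swapping phenylcarbamoyl for phenylsulfamoyl on the amine nitrogen in a ring gives a 1.1-fold higher number from compound 2 to compound 3 (0.05 log units; within the scatter) in this assay, so this exchange produces no readable change at this position. The benzylcarbamoyl compound also stays level with the sulfamoyl compound, with a 1.4-fold lower number from compound 1 to compound 3 (0.14 log units; within the scatter) as the step, and all three groups on this nitrogen remain within the scatter of one another. Nothing available explains why the exchange leaves the number in place.

The compounds shown leave open whether a carboxylic acid or a longer alkyl chain on this nitrogen would move the number beyond the scatter.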